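The compounds below may be only part of what the source reports. "The series", "measured", "known", "first", "only" and "open" are said of these compounds alone.

Measured in a functional assay on L1210 cells (Mus musculus) for inhibition, read by MTT assay; a higher number here means a weaker inhibitor, a lower number a stronger inhibitor:

compound 1 `N#CC1CN1C(=O)Nc1ccc(Cl)c(Cl)c1` gives 2600 nM
compound 2 `CCOC(=O)c1ccc(NC(=O)N2CC2C#N)cc1` gives 9700 nM
compound 3 `N#CC1CN1C(=O)NC1CCCCC1` gives 7400 nM

Compound 2 shows the highest of these three numbers, though compound 3 lies within the usual scatter of it; only compound 1 sits clearly apart, on the lower side, beyond the scatter. Compound 4 `N#CC1CN1C(=O)Nc1ccc(C(F)(F)F)cc1` differs from compound 2 by trifluoromethyl in place of ethoxycarbonyl on an aromatic carbon. Within the data shown here, no measured pair here shows this change, so the expectation rests on the three numbers alone. A step toward a lower number is expected, of a size close to the edge of the scatter: a 2.4-fold lower number from compound 2 to compound 4 (0.38 log units; beyond the scatter). Compound 4 is therefore estimated at 4000 nM, with a range from 1500 nM to 12000 nM.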

Compound 4, half-maximal inhibitory concentration: 7800 nM
For compound 4 the middle estimate is 2.0-fold (0.29 log units) below the measured one, and the stated range covers the measured number.
By their numbers in this assay, from the lowest: compound 1; then compounds 3, 4 and 2 (each within the scatter of the next).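

In this assay, trifluoromethyl in place of ethoxycarbonyl on this aromatic carbon gives a 1.2-fold lower number from compound 2 to compound 4 (0.09 log units; within the scatter) and so leaves the number unchanged within the scatter. At this position, then, the two groups cannot be told apart, although ethoxycarbonyl has 2 hydrogen-bond acceptors and trifluoromethyl has 0. This holds for this one pair only. On these data alone, whether an amine or a carboxylic acid on the same carbon would shift the number remains open. No supporting measurement is available to explain the result.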